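A few compounds are considered here, and "the series" means these few. Any claim that something is new, unique, unknown or untested is made for them only; others in the source may bear on it.

Compound 3 `COc1cc(OC)cc(-c2cn(-c3ccc(O)c(C(=O)OCCCc4ccccc4)c3)nn2)c1` stands highest of the three numbers in a functional assay on HCT-116 cells (Homo sapiens) for inhibition, read by MTT assay, with a stated time of 2 days, tested at 10 uM (a lower number here means less inhibition, a higher number more inhibition at the concentration tested (going by the name of the read-out)), giving 19%. Compound 1 `COc1cc(OC)cc(-c2cn(-c3ccc(O)c(C(=O)O)c3)nn2)c1` gives 2%, a gap beyond the scatter, while compound 2 `COc1ccc(-c2cn(-c3ccc(O)c(C(=O)Nc4cccc(C(F)(F)F)c4)c3)nn2)cc1` gives 9%, a gap that lies within the scatter of compound 3. Within the data shown here, the only step measured in one place, a number 17 percentage points higher from compound 1 to compound 3 (beyond the scatter), concerns the ester end of the molecule, not the ring changed here. Compound 4 `COc1ccc(-c2cn(-c3ccc(O)c(C(=O)OCCCc4ccccc4)c3)nn2)cc1` differs from compound 3 as 4-methoxyphenyl in place of 3,5-dimethoxyphenyl on an aromatic carbon. Among the measured compounds shown here, no measured step touches this change; compound 2 carries the entering group but also differs elsewhere, so its number alone shows nothing about it. The step of a number 4 percentage points lower from compound 3 to compound 4 (within the scatter) is therefore expected to stay within the scatter. Compound 4 is estimated at 15%, between 3% and 30%.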

Compound 4, a percentage reported as inhibition, at one concentration (the size of the read-out at that concentration, not a potency): 12%
Compound 4: the middle estimate sits 3 percentage points above what was measured, within the range that was stated.
By their numbers in this assay, from the lowest: compounds 1, 2, 4 and 3 (each within the scatter of the next, the first and the last beyond it).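

With 3-phenylpropoxy on the carbonyl carbon, the change from 3,5-dimethoxyphenyl to 4-methoxyphenyl on this aromatic carbon gives a number 7 percentage points lower from compound 3 to compound 4 (within the scatter) in this assay, so the two groups cannot be told apart here. With 4-methoxyphenyl held in place, the change at the carbonyl carbon gives a number 3 percentage points higher from compound 2 to compound 4 (within the scatter), so the ester and the amide cannot be told apart either. No available evidence bears on these results. Still open, as far as these compounds go, is how a plain phenyl or an aminophenyl group would read at this position.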